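The source may report more compounds than this note shows. Statements on the series, on what has been measured and on what is new or still open speak of the compounds shown alone.

Working notes on the series, read in a functional assay on HeLa cells (Homo sapiens) for antiproliferative activity, read by MTT assay, with a stated time of 48 h; a lower number here means a stronger inhibitor, a higher number a weaker inhibitor.

Of the compounds shown here, three have numbers so far. Compound 1, `COc1ccc2c(/C=C/C(=O)c3cc(N)c(OC)c(OC)c3)c[nH]c2c1`, gives 155 nM. Compound 2, `COc1ccc2c(/C=C(\C)C(=O)c3cc(OC)c(OC)c([Se]C)c3)c[nH]c2c1`, gives 21 nM, and compound 3, `COc1cc(C(=O)/C(C)=C/c2cn(C)c3ccccc23)cc([Se]C)c1OC`, gives 63 nM. On these three numbers compound 1 stands highest, which here means the weakest inhibitor; compound 3 is its nearest neighbour and compound 2 its furthest, and both gaps lie beyond the scatter. For the measured compounds named here, no pair among the three differs in one place only, so no single step is charted yet.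

Going by the values given here, compound 4, `COc1ccc2c(/C=C/C(=O)c3cc(OC)c(OC)c([Se]C)c3)c[nH]c2c1`, is the first such step. Relative to compound 1 the change is a group of 2 heavy atoms (1 carbon, 1 selenium; no ring) in place of one nitrogen atom, on an aromatic carbon, on the ring that carries the two methoxy groups; the indole and the enone linker are kept as in compound 1.

For this assay the expectation rests on two things: compound 2, which carries the entering group on that ring, gives 21 nM, and compound 3, which carries it there too, gives 63 nM, while compound 1 with the amino group gives 155 nM. A move toward the lower numbers is therefore expected, of moderate size, a 3.1-fold lower number from compound 1 to compound 4 (0.49 log units; beyond the scatter), with compound 4 estimated at 50 nM, in the range 20 nM to 150 nM.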

Compound 4, half-maximal inhibitory concentration: 104 nM
For compound 4 the middle estimate is 2.1-fold (0.32 log units) below the measured one, within the range that was stated.
By their numbers in this assay, from the lowest: compound 2; then compounds 3, 4 and 1 (each within the scatter of the next, the first and the last beyond it).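

For the compounds shown here, the first single change at this position shows that, in this assay, replacing amino with the group of 1 carbon and 1 selenium on this aromatic carbon, ortho to a methoxy group, gives a 1.5-fold lower number from compound 1 to compound 4 (0.17 log units; within the scatter). Going by these compounds alone, with the rest of compound 1 kept, this assay therefore does not separate the two groups at this place, although amino counts 1 hydrogen-bond donor and 1 hydrogen-bond acceptor and the entering group counts 0 of each; the earlier compounds, with no pair differing in one place only, could not show this. No supporting measurement is available to account for this result.

The compounds shown leave open whether other groups on this same aromatic carbon, such as a hydroxyl, a methylthio group or a chlorine atom, would also stay within the scatter of compound 1 or would move beyond it. Within the data shown here, they also leave open whether the same exchange would give a similar step on a different linker or core, since this one pair is its only reading.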